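Swapping Piperidin-1-yl for Pyrrolidin-1-yl in Two Pairs

The source may hold more compounds than are shown below. What is called first, only, known or untested is meant among the compounds shown, and "the series" means these compounds.

Four compounds share a thiocarbonyl carbon that carries a ring on one side and a sulfur on the other, and they differ in the chain at the far end and in that ring. Compound 1 is `CCCOP(=O)(O)OCCSC(=S)N1CCCCC1` and compound 2 is `CCCOP(=O)(O)OCCSC(=S)N1CCCC1`. Both were tested in a functional assay on PC-3 cells (Homo sapiens) for inhibition, read by MTT assay, with stated times of 18 h and 4 h; on this read-out higher numbers stand for weaker inhibition and lower numbers for stronger inhibition. For compound 1 the result in this assay is > 100000 nM, which is a limit of the assay and not a number. For compound 2 the result in this assay is likewise the limit > 100000 nM. The change between them, (pyrrolidin-1-yl in place of piperidin-1-yl on a thiocarbonyl carbon), made a step that the two limits leave unreadable from compound 1 to compound 2, because both values sit at the limit of > 100000 nM in this assay, at which 2 of the 3 values shown sit.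

Compound 3 is `CCCCCCCCCCCCCCCCOP(=O)(O)OCCSC(=S)N1CCCCC1`; how its core differs from the core of compound 1 is not broken down here. In this assay, among the compounds with values here, compound 3 gives 34300 nM, the only plain number among the three measured compounds. Compound 4, `CCCCCCCCCCCCCCCCOP(=O)(O)OCCSC(=S)N1CCCC1`, has not yet been measured. Its difference from compound 3 is pyrrolidin-1-yl in place of piperidin-1-yl on a thiocarbonyl carbon; the place is described in the same words as for compound 1 and compound 2, so this is the same change. The earlier step gives no size to lean on. The step from compound 3 to compound 4 in this assay is expected to be a 1.2-fold higher number from compound 3 to compound 4 (0.07 log units; within the scatter), close to no change. Within the data shown here, this expectation rests on compound 3, whose value 34300 nM is the only plain number available as an anchor. For compound 4 in this assay the expected value is 40000 nM, with a likely range from 15000 nM to 100000 nM.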

Compound 4, half-maximal inhibitory concentration: 65700 nM
Beside the measured number, compound 4's estimate is 1.6-fold (0.22 log units) below it; the range from low to high includes it.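

In this assay, the swap on the core of compound 3 gives a 1.9-fold higher number from compound 3 to compound 4 (0.28 log units; within the scatter), so on this core the change does not move the result beyond the usual scatter of repeated measurements. The same swap on the core of compound 1 cannot be read, because compound 1 and compound 2 both give a limit of the assay and not a number: the limit of > 100000 nM in this assay, at which 2 of the 4 values shown sit. This leaves a single readable step in the series, so it shows that the change made no clear difference on one core, but it does not show that the change carries over from one core to the other, since the pair on the core of compound 1 neither agrees nor disagrees with it.

The compounds shown carry only piperidin-1-yl or pyrrolidin-1-yl on the thiocarbonyl carbon, so it remains open how a morpholine ring or an open-chain amine such as diethylamine would read in this assay. Also open is whether the swap would give a readable step with a chain at the far end of a length between the two shown, such as an octyl chain.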